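Replacing an Aryl Group with Bromine in a Pair Level in Inhibition

A few compounds are considered here, and "the series" means these few. Any claim that something is new, unique, unknown or untested is made for them only; others in the source may bear on it.

Compound 2 `Cc1ccccc1-c1sc(N)c(C(=O)c2ccc(Cl)cc2)c1CC(C)(C)C` stands level with compound 1 `CC(C)(C)Cc1c(-c2ccc(F)cc2)sc(N)c1C(=O)c1ccc(Cl)cc1`: in an assay on CHO cells for displacement of a labelled ligand from adenosine receptor A1 (Homo sapiens), read by scintillation counting, tested at 10 uM (a higher number here means more inhibition at the concentration tested (going by the name of the read-out), a lower number less inhibition), compound 1 gives 1%, and compound 2 gives 1%, so the step of no change at the digits printed from compound 1 to compound 2 (within the scatter) stayed within the scatter. Compound 3 `CC(C)(C)Cc1c(Br)sc(N)c1C(=O)c1ccc(Cl)cc1` differs from compound 2 by bromo in place of 2-methylphenyl on an aromatic carbon. For the measured compounds named here, the only measured step swapped one aromatic group for another and moved nothing; no measured step swaps an aromatic group for a single halogen, so the expectation rests only on both known values lying near the bottom of the scale. Compound 3 is therefore expected to give 2% (range -8% to 12%), an expected step of a number 1 percentage points higher from compound 2 to compound 3 (within the scatter) within the scatter.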

Compound 3, a percentage reported as inhibition, at one concentration (the size of the read-out at that concentration, not a potency): 1%
Compound 3: middle estimate off by 1 percentage points, on the high side; low and high end bracket the measured number.
By their numbers in this assay, from the lowest: compounds 1, 2 and 3 (each within the scatter of the next).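

With bromo at this position, the reading runs no change at the digits printed from compound 2 to compound 3 (within the scatter) and no change at the digits printed from compound 1 to compound 3 (within the scatter) in this assay for the same change from the 4-fluorophenyl compound. So this carbon next to the ring sulfur can lose its whole six-membered aromatic ring, not just exchange one for another, with no visible effect. Nothing available explains this flat result. All three compounds sit near the bottom of the scale, so a change that lowers inhibition could not show here. As far as these compounds go, whether an amine or a carboxylic acid on this carbon would raise inhibition remains open.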